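This account rests on a few compounds, and the source may have more. Where it says the series, first, only, none or still open, it means among the compounds named here.

Compound 2 `COc1cc(/C=N/NC(=O)Nc2ccc(Oc3ccnc(-c4nncn4CCN(C)C)c3)c(F)c2)cc(OC)c1OC` gives 2900 nM in a functional assay on MKN-45 cells (Homo sapiens) for cytotoxicity, read by MTT assay, with a stated time of 72 h (a lower number here means a stronger inhibitor, a higher number a weaker inhibitor), the higher of the two numbers measured there. Compound 3 `CN(C)CCn1cnnc1-c1cc(Oc2ccc(NC(=O)N/N=C/c3ccc(O)cc3)cc2F)ccn1` gives 820 nM in this assay, a change of a 3.5-fold lower number from compound 2 to compound 3 (0.55 log units; beyond the scatter). Compound 1 `Cn1ncnc1-c1cc(Oc2ccc(NC(=O)N/N=C/c3ccccc3)cc2F)ccn1` sits at the limit of > 100000 nM in this assay, at which 1 of the 3 values shown sits, which is a limit of the assay and not a number; in this assay compound 1 gives > 100000 nM.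

Compound 4 `CN(C)CCn1cnnc1-c1cc(Oc2ccc(NC(=O)N/N=C/c3cccc(O)c3)cc2F)ccn1` has not been measured. Compared with compound 2 it shows (3-hydroxyphenyl in place of 3,4,5-trimethoxyphenyl on a carbon with a double bond to nitrogen). For the measured compounds named here, the one measured step that bears on this, a 3.5-fold lower number from compound 2 to compound 3 (0.55 log units; beyond the scatter), swapped the same 3,4,5-trimethoxyphenyl for a hydroxyphenyl, so a modest lowering of the number, beyond the scatter, is expected here too. Compound 4 is therefore expected to give 1000 nM, between 400 nM and 3000 nM. That would be an expected step of a 2.9-fold lower number from compound 2 to compound 4 (0.46 log units; beyond the scatter).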

Compound 4, half-maximal inhibitory concentration: 1370 nM
For compound 4 the middle estimate is 1.4-fold (0.14 log units) below the measured one; the range from low to high includes it.
By their numbers in this assay, from the lowest: compounds 3 and 4 (each within the scatter of the next); then compound 2. At a limit, above all of these: compound 1.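

A second hydroxyphenyl group also beats 3,4,5-trimethoxyphenyl at this position, with a 2.1-fold lower number from compound 2 to compound 4 (0.33 log units; beyond the scatter) in this assay, so the earlier drop was not unique to 4-hydroxyphenyl. Putting 3-hydroxyphenyl in place of 4-hydroxyphenyl gives a 1.7-fold higher number from compound 3 to compound 4 (0.22 log units; within the scatter), so this assay does not separate the two compounds. Nothing measured here accounts for either swap.

Still open is whether the hydroxyl itself matters, since an unsubstituted phenyl on the core of compound 2 is not among these compounds. An amine or a carboxylic acid on that ring is equally untested in what is shown.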